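The source may hold more compounds than are shown below. What is called first, only, known or untested is meant among the compounds shown, and "the series" means these compounds.

Compounds measured in a functional assay on CCRF-CEM cells (Homo sapiens); a lower number here means that less compound is tolerated, a higher number that more compound is tolerated:
compound 1 `Cc1cn([C@@H]2O[C@H](CO[Si](C)(C)C(C)(C)C)[C@@]3(OS(=O)(=O)C=C3N)[C@H]2O[Si](C)(C)C(C)(C)C)c(=O)n(CC2CC2)c1=O` gives 60400 nM;
compound 2 `Cc1cn([C@@H]2O[C@H](CO[Si](C)(C)C(C)(C)C)[C@@]3(OS(=O)(=O)C=C3N)[C@H]2O[Si](C)(C)C(C)(C)C)c(=O)n(CCO)c1=O` gives 11300 nM.

Within the data shown here, compound 2 stands lowest of the two numbers, and its one neighbour is compound 1, reached by a 5.3-fold lower number from compound 1 to compound 2 (0.73 log units; beyond the scatter). Compound 3 `Cc1cn([C@@H]2O[C@H](CO[Si](C)(C)C(C)(C)C)[C@@]3(OS(=O)(=O)C=C3N)[C@H]2O[Si](C)(C)C(C)(C)C)c(=O)n(CCCN(C)C)c1=O` differs from compound 2 by (dimethylamino)methyl in place of hydroxy on a saturated chain carbon, two bonds along the chain from an aromatic nitrogen. Among the measured compounds shown here, no measured step alters this part of the chain in this way; the only step known exchanges a hydroxymethyl for a cyclopropyl, a different change, so the expectation for compound 3 rests on compound 2 alone. Compound 3 is therefore expected to give about 8000 nM, within 2000 nM to 40000 nM. That expectation amounts to a 1.4-fold lower number from compound 2 to compound 3 (0.15 log units; within the scatter).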

Compound 3, half-maximal cytotoxic concentration: 10400 nM
The estimate for compound 3 lay 1.3-fold (0.11 log units) below the measured number, within the range that was stated.
By their numbers in this assay, from the lowest: compounds 3 and 2 (each within the scatter of the next); then compound 1.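

In this assay, the hydroxy of the 2-hydroxyethyl chain gives way to (dimethylamino)methyl without a change beyond the scatter (a 1.1-fold lower number from compound 2 to compound 3 (0.04 log units; within the scatter)). The 3-(dimethylamino)propyl chain of compound 3 also stands apart from the cyclopropyl of compound 1 by much the same margin as the 2-hydroxyethyl chain did (a 5.8-fold lower number from compound 1 to compound 3 (0.76 log units; beyond the scatter)). At this position, a hydroxy end and a dimethylamino end thus read alike. From the compounds shown here alone, whether a carboxylic acid or a longer chain would also read alike stays open. Nothing available explains these numbers.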